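The source may hold more compounds than are shown below. What is called first, only, known or untested is meant among the compounds shown, and "the series" means these compounds.

For the measured compounds named here, compound 3 `CCCCOc1nc(C)c(-c2ccnc(Nc3ccc(OC)cc3OC)n2)s1` gives 7860 nM in a functional assay on MV4-11 cells (Homo sapiens) for inhibition, read by resazurin assay, with a stated time of 72 h (on this read-out lower numbers stand for stronger inhibition of growth and higher numbers for weaker inhibition of growth), the highest of the three numbers measured so far. Compound 1 `COc1ccc(Nc2nccc(-c3sc(SCc4cccnc4)nc3C)n2)c(OC)c1` gives 270 nM and compound 2 `CNc1nc(C)c(-c2ccnc(Nc3ccc(OC)cc3OC)n2)s1` gives 300 nM; the step of a 29-fold higher number from compound 1 to compound 3 (1.46 log units; beyond the scatter) and the step of a 26-fold higher number from compound 2 to compound 3 (1.42 log units; beyond the scatter) were both large, whereas a 1.1-fold higher number from compound 1 to compound 2 (0.05 log units; within the scatter) stayed within the scatter. Compound 4 `COCCOc1nc(C)c(-c2ccnc(Nc3ccc(OC)cc3OC)n2)s1` differs from compound 3 by methoxy in place of ethyl on a saturated chain carbon, two bonds along the chain from an oxygen on an aromatic ring. Going by the values given here, none of the measured steps touches the chain itself: both large steps exchanged the whole butoxy group for something else, and the move from butoxy to 2-methoxyethoxy is a smaller change, so no step beyond the scatter is expected from it. Compound 4 is therefore expected to give about 5000 nM in this assay, within 2000 nM to 15000 nM, which means a step of a 1.6-fold lower number from compound 3 to compound 4 (0.20 log units; within the scatter).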

Compound 4, concentration for 50% growth inhibition: 1980 nM
Compound 4: middle estimate off by 2.5-fold (0.40 log units), on the high side, outside the stated range (below it).
By their numbers in this assay, from the lowest: compounds 1 and 2 (each within the scatter of the next); then compound 4; then compound 3.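

In this assay the chain itself proves to count, not only the exchange of the whole group: a 4.0-fold lower number from compound 3 to compound 4 (0.60 log units; beyond the scatter) comes with methoxy in place of ethyl on a saturated chain carbon. The 2-methoxyethoxy group still recovers only part of the gap, as a 6.6-fold higher number from compound 2 to compound 4 (0.82 log units; beyond the scatter) and a 7.3-fold higher number from compound 1 to compound 4 (0.87 log units; beyond the scatter) remain beyond the scatter. Nothing measured here accounts for this change. The compounds shown leave open whether an amine or a carboxylic acid at the end of the chain, or a longer chain ending in methoxy, would narrow that gap further.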